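Moving a Bromine Around a Phenoxy Ring

A few compounds are considered here, and "the series" means these few. Any claim that something is new, unique, unknown or untested is made for them only; others in the source may bear on it.

Compound 1, `O=c1cc(-n2cc(COc3ccnc4ccc(Br)cc34)nn2)c2cc(Br)ccc2o1`, gives 13300 nM in a functional assay on A549 cells (Homo sapiens) for antiproliferative activity, read by MTT assay, with a stated time of 48 h; on this read-out higher numbers stand for weaker inhibition and lower numbers for stronger inhibition.
Compound 2, `COC(=O)c1ccccc1OCc1cn(-c2cc(=O)oc3ccc(Br)cc23)nn1`, gives 5250 nM.
Compound 3, `O=c1cc(-n2cc(COc3ccccc3Br)nn2)c2cc(Br)ccc2o1`, gives 8430 nM.

Going by the values given here, compound 3 sits in the middle of these three numbers and within the scatter of both neighbours: against compound 1 the two values show only a small gap, and the single measured step, a 1.6-fold higher number from compound 2 to compound 3 (0.21 log units; within the scatter), also stays within the scatter. Compound 4, `O=c1cc(-n2cc(COc3ccc(Br)cc3)nn2)c2cc(Br)ccc2o1`, has the same atoms as compound 3 joined differently: 4-bromophenyl in place of 2-bromophenyl on an oxygen on a saturated carbon. Among the compounds with values here, no measured step moves a group around this ring; the only measured step exchanges the group at one place, and that exchange fell within the scatter. Nothing among the three measurements therefore points to a shift in this assay beyond the scatter, in either direction. Compound 4 is accordingly expected to give 8000 nM, with a range from 3000 nM to 20000 nM. That expectation corresponds to an estimated step of a 1.1-fold lower number from compound 3 to compound 4 (0.02 log units; within the scatter), essentially no change.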

Compound 4, half-maximal inhibitory concentration: 24500 nM
For compound 4 the middle estimate is 3.1-fold (0.49 log units) below the measured one; measured number above the stated range.
By their numbers in this assay, from the lowest: compounds 2, 3, 1 and 4 (each within the scatter of the next, the first and the last beyond it).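

In this assay, 4-bromophenyl in place of 2-bromophenyl on an oxygen on a saturated carbon gives a 2.9-fold higher number from compound 3 to compound 4 (0.46 log units; beyond the scatter), and since higher numbers stand for weaker inhibition, inhibition falls. This is the first step among these compounds to go beyond the scatter, and it comes with no change in the atoms, only in how they are joined, so where the bromine sits on this ring matters in this assay. Nothing measured here bears on the reason for this shift.

On these data alone, it remains open whether the methoxycarbonyl of compound 2 would respond to the same move around the ring as the bromine does. As far as these compounds go, it is also open how an amine or a carboxylic acid in place of the bromine on this ring would read in this assay.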